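The source may report more compounds than this note shows. Statements on the series, on what has been measured and on what is new or still open speak of the compounds shown alone.

Measured values (a functional assay on MCF7 cells (Homo sapiens) for antiproliferative activity, read by MTT assay, with a stated time of 48 h; on this read-out lower numbers stand for stronger inhibition and higher numbers for weaker inhibition)
Compound 1 (`COc1cc(-c2nnc3c(OC)cc(-c4ccc5[nH]ccc5c4)cn23)cc(OC)c1OC`) gives 80 nM
Compound 2 (`COc1cc(-c2nnc3c(OC(C)C)cc(-c4ccc5[nH]ccc5c4)cn23)cc(OC)c1OC`) gives 1020 nM
Compound 3 (`COc1cc(-c2nnc3c(OCC(F)(F)F)cc(-c4ccc5[nH]ccc5c4)cn23)cc(OC)c1OC`) gives 608 nM

Compound 3 stands well above compound 1 (a 7.6-fold higher number from compound 1 to compound 3 (0.88 log units; beyond the scatter)) and level with compound 2 (a 1.7-fold lower number from compound 2 to compound 3 (0.22 log units; within the scatter)). Compound 4 (`COc1cc(-c2nnc3c(OC4CC4)cc(-c4ccc5[nH]ccc5c4)cn23)cc(OC)c1OC`) carries cyclopropyl in place of 2,2,2-trifluoroethyl on an oxygen on an aromatic ring. All three measured steps concern this oxygen. Replacing methyl cost activity beyond the scatter in compound 2 (a 13-fold higher number from compound 1 to compound 2 (1.11 log units; beyond the scatter)) as well as in compound 3, and those two replacements do not separate. Compound 4 also lacks the methyl, so in this assay no step beyond the scatter is expected. The estimated step is small (a 1.4-fold lower number from compound 3 to compound 4 (0.13 log units; within the scatter)). For compound 4 the estimated value is 450 nM (expected range 150 nM to 1200 nM).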

Compound 4, half-maximal inhibitory concentration: 259 nM
For compound 4 the middle estimate is 1.7-fold (0.24 log units) above the measured one, and the stated range covers the measured number.
By their numbers in this assay, from the lowest: compound 1; then compound 4; then compounds 3 and 2 (each within the scatter of the next).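

In this assay the replacements of methyl on this oxygen now separate: cyclopropyl gives a 2.3-fold lower number from compound 3 to compound 4 (0.37 log units; beyond the scatter) and a 3.9-fold lower number from compound 2 to compound 4 (0.60 log units; beyond the scatter), so the cost seen with the two earlier groups is not fixed for every group larger than methyl. Cyclopropyl does not recover the full activity of methyl, however, with a 3.2-fold higher number from compound 1 to compound 4 (0.51 log units; beyond the scatter), and compound 1 keeps the lowest number of the four. Going by these compounds, whether ethyl or a longer chain on this oxygen, or an amine in its place, would come closer to compound 1 stays open. Nothing available here accounts for these differences.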